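The source may report more compounds than this note shows. Statements on the series, on what has been measured and on what is new or still open speak of the compounds shown alone.

Three compounds have been run so far in an ADME assay on microsomes from liver (Mus musculus) for metabolic stability, read by LC-MS, with a stated time of 30 min, tested at 1 uM; a higher number here means that more of the compound is left, a lower number that less of the compound is left. Compound 1, `O=C(NCc1ccc(S(=O)(=O)N2CCCCC2)cc1)c1cc2cnccc2s1`, gives no number there: its result is reported as "below limit of detection" (no number reported). Compound 2, `O=C(NCc1ccc(S(=O)(=O)c2ccc(F)c(F)c2)cc1)c1cc2cnccc2[nH]1`, gives 58% in this assay. Compound 3, `O=C(NCc1ccc(S(=O)(=O)c2ccccc2)cc1)c1nc2cnccc2[nH]1`, gives 7.3% in this assay, which makes it the lower of the two compounds with a number, and the gap to compound 2 lies well beyond the usual scatter. For the measured compounds named here, no two of the measured compounds differ from each other in a single place, so no step between them can be computed.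

Compound 4, `O=C(NCc1ccc(S(=O)(=O)c2ccccc2)cc1)c1cnc2nccn2c1`, is the compound still to be measured. It differs from compound 3 at one place: a group of 9 heavy atoms (6 carbon, 3 nitrogen; one five-membered aromatic ring with 2 hetero atoms, one six-membered aromatic ring with 2 hetero atoms) in place of a group of 9 heavy atoms (6 carbon, 3 nitrogen; one five-membered aromatic ring with 2 hetero atoms, one six-membered aromatic ring with 1 hetero atom), on a carbonyl carbon. The two have the same atoms, joined differently, and the change takes away the only hydrogen-bond donor of that group while adding one hydrogen-bond acceptor.

Going by the values given here, nothing among the measured compounds tells how such a rearrangement plays out in this assay, so the expectation rests on the low reading of compound 3 alone. Compound 3 sits near the floor of the scale, which leaves more room upward than downward. Compound 4 is therefore expected to give about 18% in this assay, with a plausible range from 3% to 50%. The step that this estimate implies, a number 10.7 percentage points higher from compound 3 to compound 4 (beyond the scatter), is expected to be modest, at or just beyond the usual scatter, and upward rather than downward.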

Compound 4, percent of the compound remaining: 30%
The estimate for compound 4 lay 12 percentage points below the measured number, within the range that was stated.
By their numbers in this assay, from the lowest: compound 3; then compound 4; then compound 2.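

On a carbonyl carbon whose other neighbours are an amide-type nitrogen, exchanging one group for another made of the same atoms, joined differently, gives a number 22.7 percentage points higher from compound 3 to compound 4 (beyond the scatter) in this assay. For the compounds shown here, this is the first comparison here that differs in one place, and it shows that the reading at this position depends on how these atoms are joined and not only on which atoms are present. The higher number comes with the loss of the only hydrogen-bond donor of the group and the gain of a hydrogen-bond acceptor, along with a second hetero atom in the six-membered aromatic ring, but this single pair cannot separate these changes, and no measurement here accounts for the step.

Still open, on these data alone, is how other groups at this place, such as a pyridine, a plain phenyl ring or a morpholine, would read in this assay. Also open, as far as these compounds go, is whether the same exchange would give a step of similar size in the setting of compound 1 or compound 2.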